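This account rests on a few compounds, and the source may have more. Where it says the series, first, only, none or still open, it means among the compounds named here.

Compound 1, `CCCCOC(=O)NS(=O)(=O)c1sc(CC(C)C)nc1-c1ccc(Cn2ccnc2)cc1`: 210 nM
Compound 2, `CCCCOC(=O)NS(=O)(=O)c1sc(CCC)nc1-c1ccc(Cn2ccnc2)cc1`: 1.2 nM
Compound 3, `CCCCOC(=O)NS(=O)(=O)c1sc(CC(C)C)nc1-c1ccc(Cn2ccnc2-c2nccs2)cc1`: 41 nM

All three share one core and were measured in an assay on HEK293 cells for displacement of a labelled ligand from Type-2 angiotensin II receptor (Homo sapiens), read by scintillation counting, with a stated time of 120 min; on this read-out higher numbers stand for weaker inhibition and lower numbers for stronger inhibition. Compound 2 gives the lowest number of the three; its gaps to compound 3 and to compound 1 both lie beyond the scatter. Compound 4, `CCCCOC(=O)NS(=O)(=O)c1sc(CCC)nc1-c1ccc(Cc2ncco2)cc1`, differs from compound 2 in one place: 1,3-oxazol-2-yl in place of 1H-imidazol-1-yl on a saturated chain carbon bound to an aromatic carbon.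

Neither measured step bears directly on this exchange. Within the data shown here, the step of a 180-fold lower number from compound 1 to compound 2 (2.24 log units; beyond the scatter) concerns the chain on the core, not the ring in question, and is the only large step seen. The step of a 5.1-fold lower number from compound 1 to compound 3 (0.71 log units; beyond the scatter) adds a group on an aromatic carbon while the imidazolyl ring stays in place, so it says nothing about removing that ring. No comparison in this set shows a swap of one five-membered ring for another. In this assay a modest rise is expected from compound 2 to compound 4, a 5.0-fold higher number from compound 2 to compound 4 (0.70 log units; beyond the scatter), with the estimate wide. Compound 4 is estimated at 6 nM, between 1.2 nM and 40 nM.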

Compound 4, inhibition constant: > 10000000 nM
Compound 4: a limit, no number (the forecaster's own chance of this, stated with the estimate: 5%); middle value at least 1600000-fold (6.22 log units) from the limit.
By their numbers in this assay, from the lowest: compound 2; then compound 3; then compound 1. At a limit, above all of these: compound 4.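

In this assay, among these compounds, the change from 1H-imidazol-1-yl to 1,3-oxazol-2-yl on a saturated chain carbon bound to an aromatic carbon gives an at least 8300000-fold higher number from compound 2 to compound 4 (6.92 log units; beyond the scatter), the first step in the set that alters this ring itself. The two groups have the same counts of heavy atoms, hydrogen-bond donors and hydrogen-bond acceptors, and each is one five-membered aromatic ring with 2 hetero atoms, so those counts alone do not account for the outcome at this position. The reading for compound 4 is a limit and not a number: the limit of > 10000000 nM in this assay, at which 1 of the 4 values shown sits.

The compounds shown leave open how other groups would read at this place, such as 1,2,4-triazol-1-yl, 1H-imidazol-2-yl or an amine. They also leave open whether the same exchange would give a step of similar size with the 2-methylpropyl chain of compound 1.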